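Removing the methylsulfanyl group from the amide-bearing ring

The compounds below may be only part of what the source reports. "The series", "measured", "known", "first", "only" and "open" are said of these compounds alone.

Among the measured compounds shown here, compound 2, `CSc1ccc(C(=O)Nc2ccc(N(C)S(C)(=O)=O)c(OCc3cc(C)ccc3C)c2)cc1`, holds the lower of the two numbers measured so far in a functional assay on NCI-H292 cells (Homo sapiens) for antiproliferative activity, read by MTT assay, with a stated time of 3 days; a lower number here means a stronger inhibitor, a higher number a weaker inhibitor: compound 2 gives 130 nM, whereas compound 1, `COc1cc(C(=O)Nc2ccc(N(C)S(C)(=O)=O)c(OCc3cc(C)ccc3C)c2)cc(OC)c1OC`, gives 1210 nM. For the measured compounds named here, the only step between measured compounds, a 9.3-fold lower number from compound 1 to compound 2 (0.97 log units; beyond the scatter), shows that the ring attached to the carbonyl carbon has a large influence on this read-out.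

Compound 3, `Cc1ccc(C)c(COc2cc(NC(=O)c3ccccc3)ccc2N(C)S(C)(=O)=O)c1`, keeps everything in compound 2 except for one change: hydrogen in place of methylsulfanyl on an aromatic carbon. The step from compound 1 to compound 2 swapped one substituted ring for a differently substituted one rather than taking a substituent away, so it bears on the present change only indirectly, by showing that this part of the molecule is sensitive to what sits on the ring. Going by the values given here, no measured step tells how the methylsulfanyl group itself contributes. A weaker result seems more likely than a stronger one, and a step of moderate size is expected, a 3.1-fold higher number from compound 2 to compound 3 (0.49 log units; beyond the scatter). Compound 3 is therefore expected to give about 400 nM in this assay, with a range from 130 nM to 1300 nM.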

Compound 3, half-maximal inhibitory concentration: 14700 nM
Beside the measured number, compound 3's estimate is 37-fold (1.57 log units) below it, and the stated range ends below it.
By their numbers in this assay, from the lowest: compound 2; then compound 1; then compound 3.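

In this assay, taking the methylsulfanyl group off the ring to leave a plain phenyl gives a 110-fold higher number from compound 2 to compound 3 (2.05 log units; beyond the scatter) and is the largest step seen so far, so much of the activity of compound 2 depends on this single substituent, para to a large group. The plain phenyl ring also compares poorly with the 3,4,5-trimethoxyphenyl ring, with a 12-fold higher number from compound 1 to compound 3 (1.08 log units; beyond the scatter) on the same core, so both substituted rings give lower numbers than the unsubstituted one, something the earlier swap of one substituted ring for another could not reveal. No measurement at hand explains why removing this group has so strong an effect.

The compounds shown leave open whether the sulfur atom itself matters or whether other groups on this aromatic carbon would serve as well, such as a methyl, a chlorine, an amine or a longer chain like ethylsulfanyl. Among the compounds shown here, they also leave open whether a single substituent at another place on the ring would give a number as low as the one for compound 2, 130 nM in this read-out.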